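The source may hold more compounds than are shown below. What is called first, only, known or untested is meant among the compounds shown, and "the series" means these compounds.

Compound 1 `Cc1ccccc1Nc1nc(NC2CC2)ncc1Cl` and compound 2 `Cc1ccccc1Nc1nc(NCc2ccco2)ncc1Cl` share a core and differ only in the group on one ring nitrogen, a cyclopropyl in the first and a (furan-2-yl)methyl in the second. In an ADME assay on L02 cells (Homo sapiens) for inhibition, read by CCK-8 assay, with a stated time of 48 h (a lower number here means a stronger inhibitor of growth, a higher number a weaker inhibitor of growth), compound 1 gives only a limit, > 100000 nM, not a number. Compound 2 likewise reaches only a limit, > 100000 nM. The step that the two limits leave unreadable from compound 1 to compound 2 is therefore unreadable, since both of its ends sit at the limit of > 100000 nM in this assay, at which 2 of the 3 values shown sit.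

Among the measured compounds shown here, compound 3 `CN1CCN(c2ccc(Nc3ncc(Cl)c(Nc4ccccc4)n3)nc2)CC1` carries a methylpiperazine-bearing ring in place of those small groups, and in this assay compound 3 gives 7990 nM, the only number among the three measured compounds.

Compound 4 `Cc1cccc(Nc2nc(Nc3ccc(N4CCN(C)CC4)cn3)ncc2Cl)c1` differs from compound 3 in one place: methyl in place of hydrogen on an aromatic carbon. For the measured compounds named here, none of the measured steps concerns a methyl in place of hydrogen on an aromatic carbon, and the single measured step is unreadable, so there is no evidence pointing to a change in either direction. The step of a 1.0-fold higher number from compound 3 to compound 4 (0.00 log units; within the scatter) is expected to stay within the usual scatter. Compound 4 is therefore estimated at 8000 nM, with a range from 3000 nM to 25000 nM.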

Compound 4, concentration for 50% growth inhibition: 6080 nM
Beside the measured number, compound 4's estimate is 1.3-fold (0.12 log units) above it; the measured number falls inside the stated range.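

Turning the phenyl into a 3-methylphenyl gives a 1.3-fold lower number from compound 3 to compound 4 (0.12 log units; within the scatter) in this assay, and this is the first step in the set that can be read, since the earlier step has only limits at its two ends. It shows that, in this pair, one added methyl on an aromatic carbon of this six-membered ring leaves the number where it was, as far as repeated measurements of this kind can tell, so compound 3 and compound 4 can be treated as equal in this assay. Among the compounds shown here, nothing measured so far offers a reason for this outcome.

This single pair says nothing about whether a larger or differently charged group at the same place, such as an amine, a carboxylic acid or a longer chain, would also leave the number unchanged. Compound 1 and compound 2 differ from compound 3 in more than one place, so the compounds shown also leave open which of those differences goes with the move from limits to measured numbers.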